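This account rests on a few compounds, and the source may have more. Where it says the series, first, only, none or still open, it means among the compounds named here.

Compound 1, `CC(CC(=N)S)n1nc(-c2ccccc2)ccc1=O`: 15.5%
Compound 2, `N=C(S)CCn1nc(-c2ccccc2)ccc1=O`: 53.7%
Compound 3, `N=C(S)CCCCn1nc(-c2ccccc2)ccc1=O`: 33.8%

In a functional assay on the whole organism (stomach) for inhibition, with Rattus norvegicus as the target, at a dose of 100 mg/kg by the intraduodenal route (a lower number here means less inhibition, a higher number more inhibition at the dose given (going by the name of the read-out)), compound 3 stands second highest of the three: compound 2 sits higher at 53.7% and compound 1 sits lower at 15.5%, each gap beyond the usual scatter. Compound 4 is `CC(Cn1nc(-c2ccccc2)ccc1=O)C(=N)S`, and its change from compound 3 is a group of 5 heavy atoms (3 carbon, 1 nitrogen, 1 sulfur; no ring) in place of a group of 6 heavy atoms (4 carbon, 1 nitrogen, 1 sulfur; no ring), on a saturated chain carbon bound to an aromatic nitrogen. Among the compounds with values here, two measured steps bear on this. The step of a number 38.2 percentage points higher from compound 1 to compound 2 (beyond the scatter) shows that hydrogen in place of methyl on the chain raised the read-out sharply, and compound 4 again carries a methyl in its chain. The step of a number 19.9 percentage points lower from compound 2 to compound 3 (beyond the scatter) shows that the longer chain lowered the read-out modestly, and compound 4 has the shorter chain. The two pulls oppose each other. A step of a number 5.8 percentage points lower from compound 3 to compound 4 (within the scatter) is expected in this assay, one not beyond the usual scatter. Compound 4 is therefore estimated at 28%, within a range from 10% to 50%.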

Compound 4, a percentage reported as inhibition, in the whole organism at one dose (the size of the read-out at that dose, not a potency): 86.4%
Beside the measured number, compound 4's estimate is 58.4 percentage points below it, outside the stated range (above it).
By their numbers in this assay, from the lowest: compound 1; then compound 3; then compound 2; then compound 4.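

In this assay, a methyl does not push the number down wherever it sits on the chain: methyl in place of hydrogen on a saturated chain carbon bound to a carbon with a double bond to nitrogen and a saturated chain carbon gives a number 32.7 percentage points higher from compound 2 to compound 4 (beyond the scatter), the opposite direction to the earlier methyl on the carbon bound to an aromatic nitrogen. The place of this one methyl therefore carries much of the result, with a number 70.9 percentage points higher from compound 1 to compound 4 (beyond the scatter) between the two chains of equal size, and the shorter branched group gives a number 52.6 percentage points higher from compound 3 to compound 4 (beyond the scatter) against the longer straight chain. Nothing at hand explains why the place of the methyl matters so much.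

From the compounds shown here alone, whether an ethyl or a second methyl on that same carbon would raise the number further stays open. So does whether the high number would hold with a carboxylic acid or an amide at the chain end.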